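A few compounds are considered here, and "the series" means these few. Any claim that something is new, unique, unknown or untested is made for them only; others in the source may bear on it.

The study records an ADME assay on LLC-MK2 cells (Macaca mulatta) for cytotoxicity, read by spectrophotometry and crystal violet staining, with a stated time of 4 days (on this read-out lower numbers stand for higher toxicity in this test and higher numbers for lower toxicity in this test), for two compounds built on a shared core. Compound 1 `CC(C)n1ncc2c(C(=O)Nc3c(F)cccc3F)cc(-c3cccs3)nc21` gives in this assay only a limit of the assay, > 200000 nM, and no number. Compound 2 `CC(C)n1ncc2c(C(=O)Nc3ccc(F)cc3)cc(-c3ccsc3)nc21` likewise returns in this assay only a limit, > 200000 nM. Compound 1 therefore stands at the limit rather than at a measured value, and compound 2 stands there with it, as the limit of > 200000 nM in this assay, at which 2 of the 2 values shown sit, shows. Among the measured compounds shown here, no step between measured compounds that differ in one place is available, so nothing measured yet tells how a change on the amide-type nitrogen moves the read-out. Compound 3 `CC(C)n1ncc2c(C(=O)Nc3cccc(S(N)(=O)=O)c3)cc(-c3cccs3)nc21` has not been measured in this assay. It differs from compound 1 by 3-sulfamoylphenyl in place of 2,6-difluorophenyl on an amide-type nitrogen. Because compound 1 sits at the limit > 200000 nM, there is no measured movement from which a large step could be expected. The expected step of a number no higher from compound 1 to compound 3 (the limit leaves the size open) is none beyond the usual scatter. Compound 3 is thus estimated to give 200000 nM in this assay, with a range from 100000 nM to 400000 nM, and most likely again only a limit.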

Compound 3, half-maximal cytotoxic concentration: 25000 nM
Beside the measured number, compound 3's estimate is 8.0-fold (0.90 log units) above it; the measured number lies below the stated range.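

The position on an amide-type nitrogen, whose other neighbour is the carbonyl carbon, proves able to move the read-out: in this assay, 3-sulfamoylphenyl in place of 2,6-difluorophenyl gives an at least 8.0-fold lower number from compound 1 to compound 3 (0.90 log units; beyond the scatter). On this read-out the lower number stands for higher toxicity in this test, so this change on the shared core moves compound 3 towards higher toxicity, with a measured value of 25000 nM. Compound 3 is the only compound shown to give a number, while the other two stop at a limit of the assay: the limit of > 200000 nM in this assay, at which 2 of the 3 values shown sit.

The compounds shown leave open which part of the change carries the step, the arrival of the sulfamoyl group or the departure of the two fluorines, and how far the step really reaches, as compound 1 gives a limit and no number. They also leave open whether an unsubstituted phenyl, or a phenyl carrying a carboxylic acid or an amine in place of the sulfamoyl group, would stay at the limit or lower the number as well.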